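A few compounds are considered here, and "the series" means these few. Any claim that something is new, unique, unknown or untested is made for them only; others in the source may bear on it.

For the measured compounds named here, compound 3 `c1ccc(Cn2c(CCc3c[nH]cn3)nnc2CCc2c[nH]c3ccccc23)cc1` is the only one of the three compounds for which an assay on cells for displacement of a labelled ligand from somatostatin receptor type 4 (Homo sapiens), with a stated time of 90 min (on this read-out higher numbers stand for weaker inhibition and lower numbers for stronger inhibition), returns a number: in this assay compound 3 gives 4470 nM. Compound 1 `c1ccc(Cn2c(CCc3c[nH]cn3)nnc2Cc2c[nH]c3ccccc23)cc1` reaches only a limit in this assay, > 10000 nM. Compound 2 `NCCCc1nnc(CCc2c[nH]c3ccccc23)n1Cc1ccccc1` likewise reaches only a limit in this assay, < 10000 nM. Two measured steps lead to compound 3. The step of an at least 2.2-fold lower number from compound 1 to compound 3 (0.34 log units; beyond the scatter) counts as at least modest, its size bounded by the limit of > 10000 nM in this assay, at which 1 of the 3 values shown sits. The step that the limit leaves unreadable from compound 2 to compound 3 cannot be sized, as it rests on (the limit of < 10000 nM in this assay, at which 1 of the 3 values shown sits). Compound 4 `c1ccc(Cn2c(CCc3c[nH]c4ccccc34)nnc2C2CCNCC2)cc1` has not been measured. It differs from compound 3 by piperidin-4-yl in place of 2-(1H-imidazol-4-yl)ethyl on an aromatic carbon. Neither measured step concerns an exchange of the 2-(1H-imidazol-4-yl)ethyl group for a piperidin-4-yl ring on the core, so no direction can be drawn from them, and a step beyond the scatter is not expected. Compound 4 is therefore expected to give 3000 nM in this assay, with a range of 500 nM to 15000 nM. The step of a 1.5-fold lower number from compound 3 to compound 4 (0.17 log units; within the scatter) that this estimate implies is expected to stay within the scatter.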

Compound 4, inhibition constant: > 10000 nM
Compound 4: a limit, no number (the forecaster's own chance of this, stated with the estimate: 25%); middle value at least 3.3-fold (0.52 log units) away from the limit.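

In this assay compound 4 gives > 10000 nM, which is a limit of the assay and not a number. For the compounds shown here, at this aromatic carbon the earlier compounds gave no readable exchange of 2-(1H-imidazol-4-yl)ethyl for a ring bound directly to the core; piperidin-4-yl now gives an at least 2.2-fold higher number from compound 3 to compound 4 (0.34 log units; beyond the scatter), a step whose size stays bounded: the limit of > 10000 nM in this assay, at which 2 of the 4 values shown sit. The other new step, a number no lower from compound 2 to compound 4 (the limit leaves the size open), cannot be read, and both of its values are limits.

The compounds shown leave open whether the ring itself or the loss of the ethyl chain accounts for this step: a piperidin-4-yl ring carried on an ethyl chain and a 1H-imidazol-4-yl ring bound directly to the aromatic carbon would separate the two. From the compounds shown here alone, how far compound 4 lies beyond its limit also stays open.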